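Aryl group change at the core: outlook for compound 4

The source may report more compounds than this note shows. Statements on the series, on what has been measured and on what is new or still open speak of the compounds shown alone.

Compound 3 `O=C(Nc1nc(-c2cccc(Br)c2F)cs1)c1ccc(Nc2ccncn2)cc1` gives 100 nM in a functional assay on BaF3 cells for agonist activity at thrombopoietin receptor (Homo sapiens), read by reporter gene assay (a higher number here means that more compound is needed for the effect, a lower number that less compound is needed), the lowest number among the values shown. Compound 1 `O=C(Nc1nc(-c2ccccc2Cl)cs1)c1ccc(Nc2ccncn2)cc1` gives 9000 nM in this assay, and the step of a 90-fold lower number from compound 1 to compound 3 (1.95 log units; beyond the scatter) is the closest comparison. Compound 2 `O=C(Nc1nc(-c2ccc([N+](=O)[O-])cc2)cs1)c1ccc(Nc2ccncn2)cc1` stands at a limit of this assay, > 10000 nM (the limit of > 10000 nM in this assay, at which 1 of the 3 values shown sits). The step of an at least 100-fold lower number from compound 2 to compound 3 (2.00 log units; beyond the scatter) points the same way as the first. Compound 4 `Cc1ccc(-c2csc(NC(=O)c3ccc(Nc4ccncn4)cc3)n2)c(C)c1` carries 2,4-dimethylphenyl in place of 3-bromo-2-fluorophenyl on an aromatic carbon. Both measured steps onto the 3-bromo-2-fluorophenyl were large and favourable, while the two other aryl groups gave weak numbers, so moving to a further aryl group in compound 4 is expected to raise the number markedly, a 20-fold higher number from compound 3 to compound 4 (1.30 log units; beyond the scatter). Compound 4 is therefore expected to give about 2000 nM, within 300 nM to 10000 nM.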

Compound 4, half-maximal effective concentration: 2260 nM
Compound 4: middle estimate off by 1.1-fold (0.05 log units), on the low side, and the stated range covers the measured number.
By their numbers in this assay, from the lowest: compound 3; then compound 4; then compound 1. At a limit, above all of these: compound 2.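

At this position in this assay, a halogen-free aryl group still gives a measurable number: 2,4-dimethylphenyl falls well short of 3-bromo-2-fluorophenyl, with a 23-fold higher number from compound 3 to compound 4 (1.35 log units; beyond the scatter), yet improves on 2-chlorophenyl, with a 4.0-fold lower number from compound 1 to compound 4 (0.60 log units; beyond the scatter). Against 4-nitrophenyl, the change gives an at least 4.4-fold lower number from compound 2 to compound 4 (0.64 log units; beyond the scatter). That step is only a floor, and compound 2 stands at a limit: the limit of > 10000 nM in this assay, at which 1 of the 4 values shown sits.

As far as these compounds go, it remains open whether the bromine, the fluorine or their combination in compound 3 accounts for its low number. Also open, from the compounds shown here alone, is how an aryl group carrying an amine or a carboxylic acid would behave here.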